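A Hydroxy Group Added to Compound 2

A few compounds are considered here, and "the series" means these few. Any claim that something is new, unique, unknown or untested is made for them only; others in the source may bear on it.

Going by the values given here, two related compounds have numbers so far. In a functional assay on DU-145 cells (Homo sapiens) for inhibition, read by trypan blue exclusion, with a stated time of 96 h (on this read-out lower numbers stand for stronger inhibition of growth and higher numbers for weaker inhibition of growth), compound 1 (`COc1ccc(/C=C(/SCc2ccc(Cl)cc2)C(=O)c2ccc(Br)cc2)cc1O`) gives 1000 nM and compound 2 (`COc1ccc(/C=C(/SCc2ccc(F)cc2)C(=O)c2ccc(Br)cc2)cc1`) gives 50000 nM as the higher of the two numbers, a gap beyond the scatter. Compound 3 (`COc1ccc(/C=C(/SCc2ccc(F)cc2)C(=O)c2ccc(Br)cc2)cc1O`) follows from compound 2 by the change hydroxy in place of hydrogen on an aromatic carbon and so turns 4-methoxyphenyl into 3-hydroxy-4-methoxyphenyl. Among the compounds with values here, no measured pair isolates this change. Within the data shown here, compound 1 already carries the 3-hydroxy-4-methoxyphenyl group and gives 1000 nM in this assay as the only guide, although it also differs from compound 2 elsewhere. A lower number beyond the scatter is therefore expected, and the estimated step of a 33-fold lower number from compound 2 to compound 3 (1.52 log units; beyond the scatter) points towards stronger inhibition of growth. In this assay compound 3 is expected near 1500 nM with 300 nM to 8000 nM as its estimated range.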

Compound 3, concentration for 50% growth inhibition: 1000 nM
Compound 3: middle estimate off by 1.5-fold (0.18 log units), on the high side; the range from low to high includes it.
By their numbers in this assay, from the lowest: compounds 1 and 3 (each within the scatter of the next); then compound 2.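

Compound 2 and compound 3 now isolate the change: in this assay, hydroxy in place of hydrogen on an aromatic carbon, ortho to a methoxy group, gives a 50-fold lower number from compound 2 to compound 3 (1.70 log units; beyond the scatter), a large step towards stronger inhibition of growth. With the hydroxy group in place, fluoro in place of chloro on an aromatic carbon gives no change at the digits printed from compound 1 to compound 3 (within the scatter), so this halogen swap does not separate the two compounds. Of these two single changes, only the hydroxy step lies beyond the scatter. Nothing offered here explains the size of the hydroxy step. The compounds shown leave open whether an amine or a second methoxy group on this carbon would give a similar step. They also leave open whether the hydroxy step would be the same size with chloro in place of fluoro.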